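Trifluoromethylphenyl amide in the cytotoxicity series

The source may report more compounds than this note shows. Statements on the series, on what has been measured and on what is new or still open speak of the compounds shown alone.

Compound 1 `Cc1ccc(S(=O)(=O)N[C@@H](CC(=O)NC(C)(C)C)C(=O)NCCNC(=O)c2cccc(O)c2)cc1` gives > 11000 nM in an ADME assay on HepG2 cells (Homo sapiens) for cytotoxicity (on this read-out lower numbers stand for an effect already at smaller amounts and higher numbers for an effect only at larger amounts of compound), a limit of the assay rather than a number.
Compound 2 `Cc1ccc(S(=O)(=O)N[C@@H](CC(=O)NC(C)(C)C)C(=O)NCCNC(=O)c2c(O)cccc2F)cc1` gives > 11000 nM in this assay, again a limit of the assay.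
Compound 3 `Cc1ccc(S(=O)(=O)N[C@@H](CC(=O)NC(C)(C)C)C(=O)NCCNC(=O)c2cc(C)ccn2)cc1` gives > 11000 nM in this assay, also a limit of the assay.

All three measured compounds share one core and differ only in the aryl group on the carbonyl carbon; each sits at the same limit, as the limit of > 11000 nM in this assay, at which 3 of the 3 values shown sit, records. Compound 2 therefore stands nowhere distinct among the numbers shown: its value is a limit, and the steps that touch it, a step that the two limits leave unreadable from compound 1 to compound 2 and a step that the two limits leave unreadable from compound 2 to compound 3, cannot be read in size or direction. The unmeasured compound 4 `Cc1ccc(S(=O)(=O)N[C@@H](CC(=O)NC(C)(C)C)C(=O)NCCNC(=O)c2cccc(C(F)(F)F)c2)cc1` differs from compound 2 by 3-(trifluoromethyl)phenyl in place of 2-fluoro-6-hydroxyphenyl on a carbonyl carbon. With every comparable step hidden by the limit, no shift beyond the scatter can be predicted in this assay, and the expectation is that compound 4 will likewise reach only the limit. Compound 4 is thus estimated at 15000 nM, within a range from 7000 nM to 60000 nM. For compound 4 this amounts to an expected step that the limit leaves unreadable from compound 2 to compound 4.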

Compound 4, half-maximal effective concentration: > 11000 nM
Compound 4 gave a limit, no number (the forecaster's own chance of this, stated with the estimate: 80%); the middle value is on the limit's open side.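

Compound 4 gives a limit of the assay, as do compound 1, compound 2 and compound 3, so no step from compound 4 to any of them can be read in this assay: the limit of > 11000 nM in this assay, at which 4 of the 4 values shown sit.

As far as these compounds go, whether the group on the carbonyl carbon alters this read-out at all remains open for these four compounds.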